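A few compounds are considered here, and "the series" means these few. Any claim that something is new, unique, unknown or untested is made for them only; others in the source may bear on it.

In a functional assay on MGC-803 cells (Homo sapiens) for inhibition, read by MTT assay, with a stated time of 48 h (on this read-out lower numbers stand for stronger inhibition and higher numbers for weaker inhibition), the measured compounds are:

- Compound 1 `COc1cc(NCc2ccccc2)cc(OC)c1OC` gives > 80000 nM, which is a limit and not a number.
- Compound 2 `COc1ccc(CNc2cc(OC)c(OC)c(OC)c2)cc1[N+](=O)[O-]` gives 19400 nM.
- Compound 3 `COc1ccc(CN(C(=O)C(C)Br)c2cc(OC)c(OC)c(OC)c2)cc1O` gives 120 nM.

Compound 3 has the lower of the two actual numbers, and the gap up to compound 2 lies beyond the usual scatter. Compound 4 `CC/C=C/C(=O)N(Cc1ccc(OC)c(O)c1)c1cc(OC)c(OC)c(OC)c1` carries but-1-en-1-yl in place of 1-bromoethyl on a carbonyl carbon. Within the data shown here, no measured pair isolates this change, so the expectation is only a judgement. Only compound 3 carries 1-bromoethyl, and it gives 120 nM, so a clear rise beyond the scatter is expected in this assay. The expected change is a 17-fold higher number from compound 3 to compound 4 (1.22 log units; beyond the scatter). For compound 4 the estimate is 2000 nM, with an expected range from 300 nM to 15000 nM.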

Compound 4, half-maximal inhibitory concentration: 58 nM
Compound 4: the middle estimate sits 34-fold (1.54 log units) above what was measured, outside the stated range (below it).
By their numbers in this assay, from the lowest: compound 4; then compound 3; then compound 2. At a limit, above all of these: compound 1.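

In this assay the bromine of 1-bromoethyl proves unnecessary: placing but-1-en-1-yl on the carbonyl carbon instead gives a 2.1-fold lower number from compound 3 to compound 4 (0.32 log units; beyond the scatter), a modest step. A carbon-only chain with a double bond therefore serves at this place, which a single compound carrying this kind of group could not show. No measurement here accounts for the step.

Still open, going by these compounds, is whether the double bond or the chain itself matters, since the two groups differ in both. A saturated butyl chain or an amine on the same carbonyl carbon would help separate these.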